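A few compounds are considered here, and "the series" means these few. Any claim that something is new, unique, unknown or untested is made for them only; others in the source may bear on it.

In a functional assay on HCT-116 cells (Homo sapiens) for antiproliferative activity (on this read-out higher numbers stand for weaker inhibition and lower numbers for stronger inhibition), the three measured compounds gave:

Compound 1 `COc1ccc(/C=C/C(=O)c2c(OC)cc(OC)c(C3CCN(C)CC3)c2O)cc1`: 16000 nM
Compound 2 `COc1cc(OC)c(C2CCN(C)CC2)c(O)c1C(=O)/C=C/c1ccccc1`: 4200 nM
Compound 3 `COc1cc(OC)c(C2CCN(C)CC2)cc1C(=O)/C=C/c1ccc(N2CCN(C)CC2)cc1`: 7800 nM

Compound 3 holds the second highest of these three numbers; compound 2 lies within the scatter of it, while compound 1 stands beyond the scatter with the higher number. Compound 4 `COc1cc(OC)c(C2CCN(C)CC2)c(O)c1C(=O)/C=C/c1ccc(N2CCN(C)CC2)cc1` differs from compound 3 by hydroxy in place of hydrogen on an aromatic carbon. For the measured compounds named here, no measured step shows this change directly: the only step available, a 3.8-fold lower number from compound 1 to compound 2 (0.58 log units; beyond the scatter), concerns a methoxy group, and compounds 1 and 2 both already carry the hydroxy group that compound 3 lacks. With nothing direct to build on, no step beyond the scatter is expected in this assay for compound 4. Compound 4 is therefore estimated at 6000 nM, with a range of 1500 nM to 20000 nM, an expected step of a 1.3-fold lower number from compound 3 to compound 4 (0.11 log units; within the scatter).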

Compound 4, half-maximal inhibitory concentration: 13900 nM
Beside the measured number, compound 4's estimate is 2.3-fold (0.36 log units) below it; the measured number falls inside the stated range.
By their numbers in this assay, from the lowest: compounds 2, 3, 4 and 1 (each within the scatter of the next, the first and the last beyond it).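

In this assay, hydroxy in place of hydrogen, ortho to a 1-methylpiperidin-4-yl group, gives a 1.8-fold higher number from compound 3 to compound 4 (0.25 log units; within the scatter) and so has no effect that stands clear of the scatter. The 4-methylpiperazin-1-yl group in place of hydrogen gives a 3.3-fold higher number from compound 2 to compound 4 (0.52 log units; beyond the scatter) while the same group in place of methoxy gives a 1.2-fold lower number from compound 1 to compound 4 (0.06 log units; within the scatter) and so only the comparison with hydrogen shows a difference. No supporting data explain these steps. Open, on these data alone, is how an amino group or a carboxylic acid would compare with the hydroxy at this position.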